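Aryl variation on a shared pyranone-derived core: compound 4

The source may report more compounds than this note shows. Statements on the series, on what has been measured and on what is new or still open speak of the compounds shown alone.

Of the compounds shown here, three sharing one core have been measured in a functional assay on KBVIN cells (Homo sapiens) for antiproliferative activity, read by sulforhodamine B assay, with a stated time of 3 days; a higher number here means that more compound is needed for the effect, a lower number that less compound is needed. Compound 1 `CCC1=C(O)c2c(oc(-c3ccc(C(F)(F)F)cc3)cc2=O)C(CC)(CC)C1=O` carries a trifluoromethyl on the aryl ring; in this assay compound 1 gives 10.4 uM. Compound 2 `CCOc1ccc(-c2cc(=O)c3c(o2)C(CC)(CC)C(=O)C(CC)=C3O)cc1` carries an ethoxy in its place, and compound 2 gives 7.54 uM. Compound 3 `CCCOc1ccc(-c2cc(=O)c3c(o2)C(CC)(CC)C(=O)C(CC)=C3O)cc1` carries a propoxy, and compound 3 gives 29.2 uM. The step of a 1.4-fold lower number from compound 1 to compound 2 (0.14 log units; within the scatter) lies within the scatter, while a 2.8-fold higher number from compound 1 to compound 3 (0.45 log units; beyond the scatter) and a 3.9-fold higher number from compound 2 to compound 3 (0.59 log units; beyond the scatter) are modest. Compound 2 thus holds the lowest of the three numbers, but compound 1 sits within the scatter of it, so no order between these two can be claimed.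

Compound 4 `CCC1=C(O)c2c(oc(-c3cc(C)c(C)cc3C)cc2=O)C(CC)(CC)C1=O` is not yet measured. The change from compound 2 is 2,4,5-trimethylphenyl in place of 4-ethoxyphenyl on an aromatic carbon, on an aromatic carbon next to the ring oxygen of the core. Within the data shown here, none of the measured steps tests this exact change; all three vary only the group on the aryl ring, and none moves the number by more than a modest amount. The expectation is therefore a modest step at most, with direction open, so for compound 4 the estimate is 12 uM, within 4 uM to 35 uM, corresponding to an expected step of a 1.6-fold higher number from compound 2 to compound 4 (0.20 log units; within the scatter).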

Compound 4, concentration for half-maximal effect: 4.37 uM
Estimate against measurement, compound 4: 2.7-fold (0.44 log units) above, within the range that was stated.
By their numbers in this assay, from the lowest: compounds 4, 2 and 1 (each within the scatter of the next, the first and the last beyond it); then compound 3.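

In this assay, replacing the whole aryl group gives a 1.7-fold lower number from compound 2 to compound 4 (0.24 log units; within the scatter), so this position, on an aromatic carbon next to the ring oxygen, accepts 2,4,5-trimethylphenyl in place of 4-ethoxyphenyl with no change beyond the scatter. Where the earlier compounds varied a single group on the aryl ring, this pair shows that the ether oxygen can go, with 1 hydrogen-bond acceptor leaving and 0 entering, and that a ring carrying three methyl groups can take its place, while both groups count 9 heavy atoms. This tolerance does not extend to every aryl change, as a 3.9-fold higher number from compound 2 to compound 3 (0.59 log units; beyond the scatter) still stands beyond the scatter for propoxy in place of ethoxy, and nothing shown gives a measured property that would account for either result.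

The compounds shown leave open which of the three methyl groups matters to the reading, and whether a single methyl group on the aryl ring would read like compound 4. Also open, from the compounds shown here alone, is how this position responds to an aryl ring bearing an amine, a carboxylic acid or a butoxy chain, since every aryl group here carries only alkyl, alkoxy or trifluoromethyl groups.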